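The source may report more compounds than this note shows. Statements on the series, on what has been measured and on what is new or still open speak of the compounds shown alone.

In an ADME assay on CHO cells (Cricetulus griseus) for cytotoxicity, read by LDH release (on this read-out higher numbers stand for weaker inhibition and lower numbers for stronger inhibition), compound 1 `CC(Oc1ccc(Cl)cc1Cl)C(=O)N[C@@H](C)c1ccc(F)cc1` gives 32000 nM as a measured number. Compound 2 `CC(Oc1ccc(Cl)cc1Cl)C(=O)NC(c1ccc(F)cc1)C(C)C` stands at > 100000 nM in this assay and this is a limit of the assay, not a number. The record so far therefore shows the limit of > 100000 nM in this assay, at which 1 of the 2 values shown sits, and compound 2 has no exact place on the scale.

Compound 3 `CC(Oc1ccc(Cl)cc1Cl)C(=O)NC(c1ccc(F)cc1)C1CCC1` carries cyclobutyl in place of isopropyl on a saturated chain carbon bound to an amide-type nitrogen and an aromatic carbon. Within the data shown here, no measured pair of compounds shows what a change of this kind does in this assay and so no direct guide to its size exists. No shift beyond the scatter is expected in this assay in either direction. That expectation leans on compound 2 alone, whose limit is > 100000 nM in this assay. The estimated step (an at least 1.2-fold lower number from compound 2 to compound 3 (0.09 log units; that floor lies within the scatter)) is accordingly expected to be small, and compound 3 may well return only a limit. For compound 3 the expected value is about 80000 nM with an estimated range from 35000 nM to 150000 nM in this read-out.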

Compound 3, half-maximal inhibitory concentration: > 100000 nM
Compound 3 was reported as a limit (the forecaster's own chance of this, stated with the estimate: 55%); at least 1.2-fold (0.09 log units) between middle value and limit.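

No step from compound 2 to compound 3 can be read in this assay, as both compounds are reported only as limits of the assay and not as numbers: the limit of > 100000 nM in this assay, at which 2 of the 3 values shown sit.

The compounds shown leave open whether cyclobutyl in place of isopropyl changes this read-out at all, and where compound 2 and compound 3 would sit on the scale.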